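Isobutyl in place of fluoropyridinyl: half-life expected to fall

The source may hold more compounds than are shown below. What is called first, only, known or untested is meant among the compounds shown, and "the series" means these compounds.

Compound 1 `CS(=O)(=O)Nc1ccc2c(c1)S(=O)(=O)N=C(C1=C(O)C3CCCC3N(CCC3CC3)C1=O)N2` in an in vitro ADME assay on microsomes from liver (Homo sapiens) for metabolic stability (a lower number here means that the compound disappears faster, a higher number that the compound lasts longer), gives 0.417 h.
Compound 2 `CS(=O)(=O)Nc1ccc2c(c1)S(=O)(=O)N=C(C1=C(O)C3CCCC3N(Cc3ccc(F)cn3)C1=O)N2` in this assay reaches only the limit > 1 h.
Compound 3 `CS(=O)(=O)Nc1ccc2c(c1)S(=O)(=O)N=C(C1=C(O)[C@H]3CCC[C@H]3N(Cc3ccc(F)c(F)c3)C1=O)N2` in this assay likewise reaches only the limit > 1 h.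

Compound 2 therefore stands at the upper limit of this assay, a limit rather than a number, and it shares that position with one other value shown, namely (the limit of > 1 h in this assay, at which 2 of the 3 values shown sit). Compound 4 `CC(C)CCN1C(=O)C(C2=NS(=O)(=O)c3cc(NS(C)(=O)=O)ccc3N2)=C(O)C2CCCC21` differs from compound 2 in one place: isobutyl in place of 5-fluoropyridin-2-yl on a saturated chain carbon bound to an amide-type nitrogen in a ring. Among the compounds with values here, the only measured step that bears on this place is an at least 2.3-fold higher number from compound 1 to compound 2 (0.37 log units; beyond the scatter), where a saturated cyclopropylmethyl group was exchanged for the aromatic 5-fluoropyridin-2-yl and the half-life rose beyond the scatter. The change to compound 4 runs the other way, back from the aromatic group to a saturated chain, so the expected direction for compound 4 is downward in this assay, with a size comparable to that step, though compound 2 is only a limit and the true gap may be larger. Compound 4 is therefore estimated at 0.5 h in this assay, within 0.25 h to 1.2 h, which means an expected step of an at least 2.0-fold lower number from compound 2 to compound 4 (0.30 log units; that floor lies within the scatter).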

Compound 4, half-life: 0.167 h
For compound 4 the middle estimate is 3.0-fold (0.48 log units) above the measured one; the measured number lies below the stated range.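

In this assay, this place on a saturated chain carbon bound to an amide-type nitrogen in a ring now has a step in both directions, and replacing 5-fluoropyridin-2-yl with isobutyl gives an at least 5.9-fold lower number from compound 2 to compound 4 (0.77 log units; beyond the scatter). The earlier step set a saturated group only against an aromatic one, whereas the new pair compares two saturated groups, isopropyl in place of cyclopropyl, and gives a 2.5-fold lower number from compound 1 to compound 4 (0.40 log units; beyond the scatter), so the half-life at this place also shifts beyond the scatter with no aromatic ring involved. The value of compound 2 is a limit and not a number, so the first step gives only a floor for the size of the change: the limit of > 1 h in this assay, at which 2 of the 4 values shown sit.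

On these data alone, how far compound 2 lies past its limit stays open, and so does the full size of the loss on going to compound 4. The compounds shown also leave open how an unsubstituted benzyl, a longer alkyl chain or a chain ending in an amine would behave at this place, and whether the fluorine or the ring carries the longer half-life of compound 2.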